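Replacing ethoxy with methyl on the carbonyl carbon

The compounds below may be only part of what the source reports. "The series", "measured", "known", "first", "only" and "open" are said of these compounds alone.

Within the data shown here, compound 1 `CCOC(=O)C1=C(C)NC(c2ccccc2)=CC1c1ccccc1` is one of three compounds measured in an assay on SH-SY5Y cells for inhibition of Voltage-dependent L-type calcium channel subunit alpha-1D (Homo sapiens), read by calcium flux, with a stated time of 15 min; a higher number here means a weaker inhibitor, a lower number a stronger inhibitor. In this assay compound 1 gives 18700 nM, the second highest of the three numbers. Compound 2 `CCCC1=C(C(=O)OCC)C(c2ccccc2)C=C(c2ccccc2)N1` gives 9900 nM, and compound 3 `CC1=C(C(=O)SC(C)(C)C)C(c2ccccc2)C=C(c2ccccc2)N1` gives 95800 nM. The step of a 1.9-fold lower number from compound 1 to compound 2 (0.28 log units; within the scatter) changes only an alkyl group on the core and lies within the scatter.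

Compound 4 `CC(=O)C1=C(C)NC(c2ccccc2)=CC1c1ccccc1` differs from compound 1 in a single place: methyl in place of ethoxy on a carbonyl carbon. Among the measured compounds shown here, the one measured step that touches the same position is the change from compound 1 to compound 3, which also swaps the group on the carbonyl carbon, and it read a 5.1-fold higher number from compound 1 to compound 3 (0.71 log units; beyond the scatter), a modest weakening. The step from compound 1 to compound 2 does not concern this position and offers no guidance. On this basis a small rise in the number for compound 4 is expected, though one that may not exceed the scatter. The expected step is a 1.6-fold higher number from compound 1 to compound 4 (0.21 log units; within the scatter). Compound 4 is estimated at 30000 nM, within a range from 10000 nM to 90000 nM.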

Compound 4, half-maximal inhibitory concentration: 27100 nM
Estimate against measurement, compound 4: 1.1-fold (0.04 log units) above; the measured number falls inside the stated range.
By their numbers in this assay, from the lowest: compounds 2, 1 and 4 (each within the scatter of the next, the first and the last beyond it); then compound 3.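

In this assay, a 1.4-fold higher number from compound 1 to compound 4 (0.16 log units; within the scatter), so on this carbonyl carbon methyl can stand in place of ethoxy, with its smaller count of heavy atoms and no hydrogen-bond acceptor, without a change that can be told from the scatter. The other new reading, a 3.5-fold lower number from compound 3 to compound 4 (0.55 log units; beyond the scatter), shows that the higher number seen with (tert-butyl)sulfanyl does not come simply from removing ethoxy, since methyl also removes it and does not share that higher number. No measurement shown here gives a reason for either step.

The compounds shown place only ethoxy, methyl and (tert-butyl)sulfanyl on this carbonyl carbon, so the outcome with an amine or a carboxylic acid there remains open. From the compounds shown here alone, it is also open whether a longer chain in place of methyl, or ethylsulfanyl in place of (tert-butyl)sulfanyl, would shift the number.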